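A few compounds are considered here, and "the series" means these few. Any claim that something is new, unique, unknown or untested is made for them only; others in the source may bear on it.

Working notes on the hydrazone series. The series is read in a functional assay on HCT-8 cells (Homo sapiens) for cytotoxicity, read by MTT assay, with a stated time of 72 h; on this read-out higher numbers stand for weaker inhibition and lower numbers for stronger inhibition. Compound 1 `O=[N+]([O-])c1ccc(O)c(/C=N/Nc2nc3ccccc3s2)c1` gives 13500 nM in this assay. Compound 2 `COc1cc(/C=N/Nc2nc3ccccc3s2)ccc1O` reaches only the limit of this assay, > 16700 nM, which is a limit and not a number. The limit is noted as the limit of > 16700 nM in this assay, at which 1 of the 2 values shown sits. Among the compounds with values here, no step between the two measured compounds is computed, so the two values show only that compound 1 returns a number while compound 2 does not.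

Compound 3 `Oc1ccc(/C=N/Nc2nc3ccccc3s2)cc1O` has not yet been measured in this assay. It differs from compound 2 by hydrogen in place of methyl on an oxygen on an aromatic ring. Since compound 2 stands at a limit, the size of the step is open; the expectation is of no change beyond the scatter, with the estimate for compound 3 left at the weak end of this assay. On that basis the step from compound 2 to compound 3 is estimated as an at least 1.1-fold lower number from compound 2 to compound 3 (0.04 log units; that floor lies within the scatter). Compound 3 is expected to give about 15000 nM in this assay, with a range from 5000 nM to 45000 nM, and a fair chance that this assay again returns only a limit.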

Compound 3, half-maximal inhibitory concentration: > 17500 nM
Compound 3: only a limit was reported; the forecaster's own chance of this, stated with the estimate: 50%; middle value at least 1.1-fold (0.06 log units) from the limit.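

In this assay compound 3 gives > 17500 nM, which is a limit and not a number. Compound 2 likewise stands at a limit, > 16700 nM. No step can be read between compound 2 and compound 3. The compounds shown leave open whether hydroxy in place of methoxy changes the value in this assay at all.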